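From 4-aminophenyl to 3-aminophenyl: a working note

The source may hold more compounds than are shown below. What is called first, only, known or untested is meant among the compounds shown, and "the series" means these compounds.

- compound 1 `Cc1ccc(S(=O)(=O)c2nc3ccccc3nc2Nc2cccc(N)c2)cc1` gives 10600 nM
- compound 2 `Nc1ccc(Nc2nc3ccccc3nc2S(=O)(=O)c2ccc(Br)cc2)cc1` gives 4080 nM

In a functional assay on KB cells (Homo sapiens) for cytotoxicity, read by MTT assay, with a stated time of 72 h (on this read-out lower numbers stand for stronger inhibition and higher numbers for weaker inhibition), compound 2 at 4080 nM holds the lower of the two numbers, and compound 1 stands higher by a gap beyond the scatter. Compound 3 `Nc1cccc(Nc2nc3ccccc3nc2S(=O)(=O)c2ccc(Br)cc2)c1` is not yet measured. Against compound 2, it carries 3-aminophenyl in place of 4-aminophenyl on a nitrogen on an aromatic ring and has the same atoms, joined differently. For the measured compounds named here, no measured pair differs in one place only, so this assay offers no direct size for this change. The expected step of a 1.6-fold higher number from compound 2 to compound 3 (0.20 log units; within the scatter) is a modest one towards a higher number. That direction is a weak expectation, resting only on compound 1 at 10600 nM standing higher. For compound 3 the estimated value is 6500 nM with an expected range from 2500 nM to 15000 nM.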

Compound 3, half-maximal inhibitory concentration: 5340 nM
The estimate for compound 3 lay 1.2-fold (0.09 log units) above the measured number; the measured number falls inside the stated range.
By their numbers in this assay, from the lowest: compounds 2, 3 and 1 (each within the scatter of the next, the first and the last beyond it).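

In this assay, 3-aminophenyl in place of 4-aminophenyl on a nitrogen on an aromatic ring gives a 1.3-fold higher number from compound 2 to compound 3 (0.12 log units; within the scatter) and thus no difference that can be told from the scatter. For this pair, the placement of the amino group on the ring leaves the cytotoxicity number unresolved from that of the parent, a reading that rests on this single pair. For the compounds shown here, compound 3 also provides the first single-place comparison for the other substituent: bromo in place of methyl on an aromatic carbon gives a 2.0-fold lower number from compound 1 to compound 3 (0.30 log units; within the scatter) and this too is printed as within the scatter.

Still open, going by these compounds, is whether a hydroxyl or an acetamide in place of the amino group, or chloro or trifluoromethyl in place of bromo, would give a step beyond the scatter. No measurement available here speaks to what lies behind either step.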